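Shifting One Methoxy Group on a Growth Inhibitor

The source may report more compounds than this note shows. Statements on the series, on what has been measured and on what is new or still open speak of the compounds shown alone.

Compound 1 `COc1cccc(/C=C/C(=O)/C=C/c2ccc(OCc3cn(CCCCCOc4cc(=O)oc5ccccc45)nn3)c(OC)c2)c1` has been tested in a functional assay on THP-1 cells (Homo sapiens) for inhibition, read by sulforhodamine B assay, with a stated time of 48 h, tested at 50 uM (on this read-out higher numbers stand for more inhibition of growth at the one concentration tested and lower numbers for less inhibition of growth), where compound 1 gives 37%. Going by the values given here, that is the lower of the two numbers so far: compound 2 `COc1ccccc1/C=C/C(=O)/C=C/c1ccc(OCc2cn(CCCOc3cc(=O)oc4ccccc34)nn2)c(OC)c1` gives 50%, a gap beyond the usual scatter of such measurements. Compound 3 `COc1ccccc1/C=C/C(=O)/C=C/c1ccc(OCc2cn(CCCCCOc3cc(=O)oc4ccccc34)nn2)c(OC)c1` has not yet been measured. It has the same atoms as compound 1, joined differently: 2-methoxyphenyl in place of 3-methoxyphenyl on a double-bonded chain carbon bound to a double-bonded chain carbon. In words, 2-methoxyphenyl stands in place of 3-methoxyphenyl on a double-bonded chain carbon bound to a double-bonded chain carbon. Among the compounds with values here, no measured pair shows this swap alone, so there is no direct guide to its size. Compound 2 also carries 2-methoxyphenyl and reaches 50%, but it is not otherwise identical to compound 3. This offers only a weak hint of a modest rise in this assay, one that may not clear the scatter. The expected change is a number 5 percentage points higher from compound 1 to compound 3 (within the scatter). For compound 3 the estimated value is 42%, with an expected range from 28% to 56%.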

Compound 3, percent growth inhibition at one concentration: 37%
Beside the measured number, compound 3's estimate is 5 percentage points above it; low and high end bracket the measured number.
By their numbers in this assay, from the lowest: compounds 1 and 3 (each within the scatter of the next); then compound 2.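

In this assay the step reads no change at the digits printed from compound 1 to compound 3 (within the scatter) when 2-methoxyphenyl stands in place of 3-methoxyphenyl on a double-bonded chain carbon bound to a double-bonded chain carbon. Going by these compounds alone, this is the first pair that shows the swap alone, and it shows that, at the single concentration tested, the two methoxyphenyl groups cannot be told apart at this place on the core of compound 1, while carrying 2-methoxyphenyl is not enough on its own for compound 3 to match compound 2 (50%). Nothing available gives a reason for this result.

Going by these compounds, whether the swap would read the same on the chain of compound 2 remains open, as does how it would read at other concentrations, since one concentration cannot show how the full response to dose compares. Also open, on these data alone, is whether a quite different group at this place, such as an amine or a carboxylic acid on the ring in place of the methoxy group, would move the number beyond the usual scatter.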